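Thiourea in Place of Nitrobenzyl on the Ring Nitrogen

This account rests on a few compounds, and the source may have more. Where it says the series, first, only, none or still open, it means among the compounds named here.

Within the data shown here, compound 1 `NC(=O)c1c(NC(=O)c2ccccc2Cl)sc2c1CCN(Cc1ccc([N+](=O)[O-])cc1)C2` is the only compound of the two with a number in a functional assay on HeLa cells (Homo sapiens) for antiproliferative activity, with a stated time of 24 h; a higher number here means a weaker inhibitor, a lower number a stronger inhibitor: compound 1 gives 46100 nM. Compound 2 `NC(=O)c1c(NC(=O)c2ccc(C(F)(F)F)cc2)sc2c1CCN(Cc1ccc(Cl)cc1)C2` reaches only the limit of this assay, > 50000 nM, which is a limit and not a number (the limit of > 50000 nM in this assay, at which 1 of the 2 values shown sits). Compound 3 `COc1ccccc1NC(=S)N1CCc2c(sc(NC(=O)c3ccccc3Cl)c2C(N)=O)C1` differs from compound 1 in one place: a group of 11 heavy atoms (8 carbon, 1 nitrogen, 1 oxygen, 1 sulfur; one six-membered aromatic ring of carbon only) in place of a group of 10 heavy atoms (7 carbon, 1 nitrogen, 2 oxygen; one six-membered aromatic ring of carbon only), on an amine nitrogen in a ring. Among the measured compounds shown here, no measured step is available, so the expected step of a 1.3-fold lower number from compound 1 to compound 3 (0.12 log units; within the scatter) is set to little change beyond the scatter, given how weak compound 1 already is at 46100 nM. Compound 3 is therefore expected at 35000 nM, within a range from 12000 nM to 50000 nM, with a real chance that only a limit is returned.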

Compound 3, half-maximal inhibitory concentration: > 50000 nM
Compound 3: only a limit was reported (the forecaster's own chance of this, stated with the estimate: 35%); at least 1.4-fold (0.15 log units) between middle value and limit.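

On the amine nitrogen in a ring, replacing 4-nitrobenzyl with the thiourea group brings no gain in this assay: compound 3 gives > 50000 nM, which is a limit and not a number. The change reads as an at least 1.0-fold higher number from compound 1 to compound 3 (0.03 log units; that floor lies within the scatter), so its true size stays unfixed and the replacement offers no route to a stronger compound. Values in the series now gather at the top of the read-out: the limit of > 50000 nM in this assay, at which 2 of the 3 values shown sit.

On these data alone, whether a longer chain ending in an aliphatic amine or a carboxylic acid on this nitrogen would give a measurable number stays open.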